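The source may report more compounds than this note shows. Statements on the series, on what has been measured and on what is new or still open speak of the compounds shown alone.

Of the compounds shown here, three built on one shared core have been tested in a functional assay on U-87MG ATCC cells (Homo sapiens) for cytotoxicity, read by MTT assay, with a stated time of 48 h; a lower number here means a stronger inhibitor, a higher number a weaker inhibitor. Compound 1 `Cn1cc(/C=C2/C(=O)Nc3ccccc32)c2cc(Nc3nccc(-c4ccccc4)n3)ccc21` gives 14100 nM. Compound 2 `COc1ccc(-c2ccnc(Nc3ccc4c(c3)c(/C=C3/C(=O)Nc5ccccc53)cn4C)n2)cc1` reaches only the limit of the assay, > 100000 nM. Compound 3 `Cn1cc(/C=C2/C(=O)Nc3ccccc32)c2cc(Nc3nccc(-c4ccc(Cl)cc4)n3)ccc21` gives 5820 nM, the lowest of the two numbers recorded, with compound 1 standing nearest to it. The step of an at least 7.0-fold higher number from compound 1 to compound 2 (0.85 log units; beyond the scatter) is at least modest; the step of a 2.4-fold lower number from compound 1 to compound 3 (0.38 log units; beyond the scatter) is modest; and the step of an at least 17-fold lower number from compound 2 to compound 3 (1.23 log units; beyond the scatter) is large, one end of it resting on the limit (the limit of > 100000 nM in this assay, at which 1 of the 3 values shown sits).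

Compound 4 `Cn1cc(/C=C2/C(=O)Nc3ccccc32)c2cc(Nc3nccc(-c4ccc(Cl)cc4Cl)n3)ccc21` differs from compound 3 by chloro in place of hydrogen on an aromatic carbon. Going by the values given here, the one measured step that adds a chloro to this ring, a 2.4-fold lower number from compound 1 to compound 3 (0.38 log units; beyond the scatter), was modest and downward; no measured step puts a group ortho to a large group, so the added chloro carries more uncertainty than the earlier one. A step of the same kind but smaller, a 1.5-fold lower number from compound 3 to compound 4 (0.16 log units; within the scatter), is therefore expected in this assay, with the possibility that it falls within the scatter. Compound 4 is estimated at 4000 nM, with a range from 1500 nM to 15000 nM.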

Compound 4, half-maximal inhibitory concentration: 36800 nM
Beside the measured number, compound 4's estimate is 9.2-fold (0.96 log units) below it; the whole stated range lies below it.
By their numbers in this assay, from the lowest: compound 3; then compound 1; then compound 4. At a limit, above all of these: compound 2.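

Going from 4-chlorophenyl to 2,4-dichlorophenyl, which places a chloro ortho to a large group and meta to a chloro group, runs against the earlier chloro addition in this assay, with a 6.3-fold higher number from compound 3 to compound 4 (0.80 log units; beyond the scatter) as the step. So the same change, chloro in place of hydrogen on this ring, lowers the number at one place and raises it at the other, and its direction cannot be carried from one place to the next. The second chloro also more than cancels the first, leaving a 2.6-fold higher number from compound 1 to compound 4 (0.42 log units; beyond the scatter) against the plain phenyl, while compound 2 remains a limit and not a number, so that an at least 2.7-fold lower number from compound 2 to compound 4 (0.43 log units; beyond the scatter) is only a bound, one end of it resting there: the limit of > 100000 nM in this assay, at which 1 of the 4 values shown sits.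

The compounds shown leave open whether the rise belongs to the ortho place alone or to the two chloro groups taken together. A lone fluoro or methyl ortho to a large group, with no chloro meta to it, would separate those two readings, and a methoxy at that place would show whether the ortho step follows the same course as the chloro.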